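This account rests on a few compounds, and the source may have more. Where it says the series, first, only, none or still open, it means among the compounds named here.

Of the compounds shown here, three have so far been measured in an ADME assay on HepG2 cells (Homo sapiens) for cytotoxicity, read by luminescence, CellTiter-Glo and ATP content, with a stated time of 72 h; a higher number here means that more compound is needed for the effect, a lower number that less compound is needed. Compound 1 `COc1cccc(Oc2ccc3c(NCCCNCc4cc(F)ccc4OC)ccnc3c2)c1` gives 7100 nM there. Compound 2 `Fc1ccc(Cc2ccc3c(NCCCNCc4ccco4)ccnc3c2)c(Cl)c1` gives 5730 nM in this assay. Compound 3 `COc1ccc(F)cc1CNCCCNc1ccnc2cc(CCc3ccccc3)ccc12` gives 4240 nM in this assay. Compound 3 therefore has the lowest of the three numbers, but its gaps to compound 2 and to compound 1 both lie within the scatter, so nothing separates the three. Within the data shown here, the only step between compounds that differ in one place, a 1.7-fold lower number from compound 1 to compound 3 (0.22 log units; within the scatter), is likewise within the scatter.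

Compound 4 `COc1ccc(F)cc1CNCCCNc1ccnc2cc(Cc3ccc(F)cc3Cl)ccc12` differs from compound 3 in one place: 2-chloro-4-fluorophenyl in place of benzyl on a saturated chain carbon bound to an aromatic carbon. The group that enters is the same 2-chloro-4-fluorobenzyl that compound 2 carries on the shared core, and compound 2 and compound 3 give numbers within the scatter of each other. Among the measured compounds shown here, no measured step bears directly on this exchange; the one measured step at this position, a 1.7-fold lower number from compound 1 to compound 3 (0.22 log units; within the scatter), stayed within the scatter. The step from compound 3 to compound 4 is thus expected to be a 1.2-fold higher number from compound 3 to compound 4 (0.07 log units; within the scatter), with no direction beyond the scatter. Compound 4 is expected to give about 5000 nM in this assay, within a range from 2500 nM to 10000 nM.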

Compound 4, half-maximal effective concentration: 2460 nM
Compound 4: the middle estimate sits 2.0-fold (0.31 log units) above what was measured, and the stated range ends above it.
By their numbers in this assay, from the lowest: compounds 4, 3, 2 and 1 (each within the scatter of the next, the first and the last beyond it).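

In this assay the exchange at this position stays within the scatter, a 1.7-fold lower number from compound 3 to compound 4 (0.24 log units; within the scatter), so this step alone does not separate 2-chloro-4-fluorobenzyl from phenethyl on the shared core. Among these compounds, compound 4 nevertheless gives the only steps beyond the scatter in this set, both modest: a 2.9-fold lower number from compound 1 to compound 4 (0.46 log units; beyond the scatter) with 2-chloro-4-fluorobenzyl in place of 3-methoxyphenoxy on an aromatic carbon, and a 2.3-fold lower number from compound 2 to compound 4 (0.37 log units; beyond the scatter) with 5-fluoro-2-methoxyphenyl in place of furan-2-yl on a saturated chain carbon bound to an amine nitrogen. Nothing shown gives a cause for these steps.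

The compounds shown leave open whether an amine or a carboxylic acid on this aromatic carbon would move the number further. They also leave open how a longer chain between the two amine nitrogens would read in this assay.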